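Adding Back a Fluorine to Compound 3

The source may hold more compounds than are shown below. What is called first, only, known or untested is meant among the compounds shown, and "the series" means these compounds.

Of the compounds shown here, three sharing one core have been measured in an assay on cells for inhibition of Voltage-dependent T-type calcium channel subunit alpha-1G (Homo sapiens), read by patch clamp; a lower number here means a stronger inhibitor, a higher number a weaker inhibitor. Compound 1 `CN(C)CCCCCSC1=Nc2ccccc2C(CC(=O)NCc2ccccc2)N1c1ccc(-c2ccc(F)cc2)cc1` gives 250 nM. Compound 2 `CN(C)CCCCCSC1=Nc2ccccc2C(CC(=O)NCc2ccccc2)N1c1ccc(-c2ccccc2)cc1` carries hydrogen where compound 1 carries fluoro. Compound 2 gives 7770 nM; that single exchange brought a 31-fold higher number from compound 1 to compound 2 (1.49 log units; beyond the scatter). Compound 3 `CN(C)CCCCCSC1=Nc2ccccc2C(CC(=O)NCc2ccc(F)cc2)N1c1ccc(-c2ccccc2)cc1`, which carries a fluoro on a different aromatic carbon, gives 27400 nM, the highest of the three numbers, with compound 2 nearest and compound 1 furthest; the exchange was a 3.5-fold higher number from compound 2 to compound 3 (0.55 log units; beyond the scatter).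

Compound 4 `CN(C)CCCCCSC1=Nc2ccccc2C(CC(=O)NCc2ccc(F)cc2)N1c1ccc(-c2ccc(F)cc2)cc1` has not yet been measured. It differs from compound 3 by fluoro in place of hydrogen on an aromatic carbon. This is the same fluoro, in the same place, whose removal set compound 2 apart from compound 1, so the step that bears most directly is a 31-fold higher number from compound 1 to compound 2 (1.49 log units; beyond the scatter); read in reverse, it points to a much lower number. Among the measured compounds shown here, the step of a 3.5-fold higher number from compound 2 to compound 3 (0.55 log units; beyond the scatter) concerns the other fluoro and says only that compound 3 starts from a high number. Compound 4 is therefore expected to give a markedly lower number, a step of about a 27-fold lower number from compound 3 to compound 4 (1.44 log units; beyond the scatter). The estimate for compound 4 in this assay is 1000 nM, in a range from 300 nM to 4000 nM.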

Compound 4, half-maximal inhibitory concentration: 400 nM
The estimate for compound 4 lay 2.5-fold (0.40 log units) above the measured number, and the stated range covers the measured number.
By their numbers in this assay, from the lowest: compounds 1 and 4 (each within the scatter of the next); then compound 2; then compound 3.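

The step of a 69-fold lower number from compound 3 to compound 4 (1.84 log units; beyond the scatter) shows that the change from phenyl to 4-fluorophenyl at this position lowers the number on a second core, so the large effect is no longer tied to the pair of compound 1 and compound 2. Read in the same direction on both cores, the two steps agree in size: the same change on two cores in this assay, a 31-fold higher number (1.49 log units; beyond the scatter) from compound 1 to compound 2 and a 69-fold higher number (1.84 log units; beyond the scatter) from compound 4 to compound 3, 2.2-fold (0.34 log units) apart, within the scatter of two such steps. The other fluoro gives a less clear picture, since a 1.6-fold higher number from compound 1 to compound 4 (0.20 log units; within the scatter) lies within the scatter while a 3.5-fold higher number from compound 2 to compound 3 (0.55 log units; beyond the scatter) lies beyond it, yet the gap between these two steps cannot be told from the scatter, so the data do not show that the effect of this fluoro depends on what sits at the 4-fluorophenyl position: the same change on two cores in this assay, a 3.5-fold higher number (0.55 log units; beyond the scatter) from compound 2 to compound 3 and a 1.6-fold higher number (0.20 log units; within the scatter) from compound 1 to compound 4, 2.2-fold (0.34 log units) apart, within the scatter of two such steps.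

The compounds shown carry only hydrogen or fluoro at this position, which leaves open whether a chlorine atom, a methyl group or a methoxy group there would also lower the number. Among the compounds shown here, they also leave open whether the step would hold with a shorter chain in place of the one carrying the dimethylamino group.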